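Adding an amino group to compound 2

The compounds below may be only part of what the source reports. "The series", "measured", "known", "first", "only" and "open" are said of these compounds alone.

Compound 1 `COc1ccc(NCc2cncn2Cc2ccc(-c3ccccc3)cc2N)cc1-c1ccccc1`: > 1000 nM
Compound 2 `c1ccc(-c2ccc(Cn3cncc3CNc3ccc(-c4cncs4)c(-c4ccccc4)c3)cc2)cc1`: > 1000 nM

In a toxicity assay on NIH3T3 cells (Mus musculus) for cytotoxicity, read by resazurin assay (a lower number here means that less compound is needed, a higher number that more compound is needed for the effect), compound 2 gives > 1000 nM, which is a limit of the assay and not a number. Both measured compounds stand in the same place: the limit of > 1000 nM in this assay, at which 2 of the 2 values shown sit. Compound 3 `Nc1cc(-c2ccccc2)ccc1Cn1cncc1CNc1ccc(-c2cncs2)c(-c2ccccc2)c1` has amino in place of hydrogen on an aromatic carbon. Compound 1 also carries an amino group and gives > 1000 nM, again only a limit. Among the measured compounds shown here, no measured step shows what this change does, so no change beyond the scatter is expected in this assay. The expected step is small, a step that the limit leaves unreadable from compound 2 to compound 3. For compound 3 the estimate is 1500 nM, with an expected range of 500 nM to 5000 nM.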

Compound 3, half-maximal effective concentration: > 1000 nM
Compound 3: no number, only a limit (the forecaster's own chance of this, stated with the estimate: 80%); the middle value does not contradict the limit.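

In this assay compound 3 gives > 1000 nM, again a limit of the assay and not a number, so the steps to it from compound 1 and compound 2 cannot be read. The compounds shown leave open how much of each is needed for the effect, and so whether the amino group makes any difference.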